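Extending the Butoxy Chain: From Butoxy to a Longer Chain

The compounds below may be only part of what the source reports. "The series", "measured", "known", "first", "only" and "open" are said of these compounds alone.

Of the compounds shown here, two have so far been measured in an assay on cells for antagonist activity at transient receptor potential cation channel subfamily V member 1 (Homo sapiens), read by FLIPR and calcium flux, with a stated time of 6 min; a lower number here means a stronger inhibitor, a higher number a weaker inhibitor. Compound 1 `CC(C(=O)NCc1ccc(C(C)(C)C)cc1N1CCN(c2ccccc2)CC1)c1ccc(NS(C)(=O)=O)c(F)c1` gives 0.8 nM. For the measured compounds named here, compound 2 `CCCCOc1cc(C(C)(C)C)ccc1CNC(=O)C(C)c1ccc(NS(C)(=O)=O)c(F)c1` gives 1.4 nM, the higher of the two numbers, though the single recorded step, a 1.8-fold higher number from compound 1 to compound 2 (0.24 log units; within the scatter), lies within the scatter. Compound 3 `CCCCCCOc1cc(C(C)(C)C)ccc1CNC(=O)C(C)c1ccc(NS(C)(=O)=O)c(F)c1` differs from compound 2 by ethyl in place of hydrogen on a saturated chain carbon, four bonds along the chain from an oxygen on an aromatic ring. Going by the values given here, no measured step addresses the length of this chain: the only step available replaces 4-phenylpiperazin-1-yl with butoxy and itself moves the number within the scatter. With no evidence of sensitivity to what sits on that aromatic oxygen, the change from compound 2 to compound 3 is expected to give no step beyond the scatter in this assay, an estimated 1.1-fold higher number from compound 2 to compound 3 (0.03 log units; within the scatter). Compound 3 is therefore expected to give about 1.5 nM, with a range from 0.5 nM to 4.5 nM.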

Compound 3, inhibition constant: 0.5 nM
Beside the measured number, compound 3's estimate is 3.0-fold (0.48 log units) above it; low and high end bracket the measured number.
By their numbers in this assay, from the lowest: compounds 3, 1 and 2 (each within the scatter of the next, the first and the last beyond it).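

Among the compounds shown, this is the first step to pass beyond the scatter in this assay: ethyl in place of hydrogen, four bonds along the chain from the oxygen on the aromatic ring, gives a 2.8-fold lower number from compound 2 to compound 3 (0.45 log units; beyond the scatter). The far end of this chain therefore matters to the number, which the earlier step could not show, while the swap of 4-phenylpiperazin-1-yl for hexyloxy gives a 1.6-fold lower number from compound 1 to compound 3 (0.20 log units; within the scatter), so those two compounds cannot be told apart. Nothing available accounts for the effect of the added ethyl.

Butoxy and hexyloxy alone define no trend with chain length. As far as these compounds go, whether a longer chain such as octyloxy would lower the number further or raise it again remains open, as does the effect of an amine or a carboxylic acid at the chain end.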